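This account rests on a few compounds, and the source may have more. Where it says the series, first, only, none or still open, it means among the compounds named here.

Measured compounds:
compound 1 `O=C(Nc1ccccc1)Nc1ccc(C(=O)NO)cc1` – 530 nM
compound 2 `O=C(Nc1ccc(Cl)cc1)Nc1ccc(C(=O)NO)cc1` – 870 nM
compound 3 `COc1ccc(NC(=O)Nc2ccc(C(=O)NO)cc2)cc1` – 4790 nM

In a functional assay on NAMALVA cells (Homo sapiens) for cytotoxicity, read by MTT assay, with a stated time of 72 h (a higher number here means a weaker inhibitor, a lower number a stronger inhibitor), compound 3 stands highest of the three numbers: a 5.5-fold higher number from compound 2 to compound 3 (0.74 log units; beyond the scatter) and a 9.0-fold higher number from compound 1 to compound 3 (0.96 log units; beyond the scatter), both beyond the scatter. Compound 4 `COc1ccc(NC(=O)Nc2ccc(/C=C/C(=O)NO)cc2)cc1` differs from compound 3 in one place: 2-(hydroxycarbamoyl)ethenyl in place of hydroxycarbamoyl on an aromatic carbon. For the measured compounds named here, none of the measured steps touches this part of the molecule; all three concern only the chloro or methoxy group, so they give no direct guide to the present change, which has to be judged on the structures alone. Compound 4 is expected to give 1500 nM, within 300 nM to 6000 nM. The expected step is a 3.2-fold lower number from compound 3 to compound 4 (0.50 log units; beyond the scatter), a modest fall in the number that could still sit close to the scatter.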

Compound 4, half-maximal inhibitory concentration: 460 nM
Estimate against measurement, compound 4: 3.3-fold (0.51 log units) above, within the range that was stated.
By their numbers in this assay, from the lowest: compounds 4, 1 and 2 (each within the scatter of the next); then compound 3.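

In this assay, 2-(hydroxycarbamoyl)ethenyl in place of hydroxycarbamoyl gives a 10-fold lower number from compound 3 to compound 4 (1.02 log units; beyond the scatter), a large step. For the compounds shown here, the earlier steps concerned only the chloro and methoxy groups, so this is the first sign that the number also responds to a change at the hydroxycarbamoyl end of the molecule. Nothing available accounts for this step.

Going by these compounds alone, the change is seen only with the methoxy group present, so its effect on compound 1 or compound 2 stays open. As far as these compounds go, how a longer chain ending in hydroxycarbamoyl, or a carboxylic acid in its place, would read is also open.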